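Lengthening the hydroxy chain from compound 3 to compound 4

This account rests on a few compounds, and the source may have more. Where it says the series, first, only, none or still open, it means among the compounds named here.

Measured in an ADME assay on Vero cells (Chlorocebus sabaeus) for inhibition, read by fluorescence and resazurin assay, with a stated time of 24 h; a higher number here means that more compound is tolerated, a lower number that less compound is tolerated:
compound 1 `O=[N+]([O-])c1ccc2nn(Cc3ccccc3)c(OCCBr)c2c1`: "not determined" (no result reported)
compound 2 `O=[N+]([O-])c1ccc2nn(Cc3ccccc3)c(OCCCBr)c2c1`: 539000 nM
compound 3 `O=[N+]([O-])c1ccc2nn(Cc3ccccc3)c(OCCO)c2c1`: > 300000 nM

Compound 3 gives > 300000 nM here, which is a limit of the assay and not a number. Compound 4 `O=[N+]([O-])c1ccc2nn(Cc3ccccc3)c(OCCCO)c2c1` has hydroxymethyl in place of hydroxy on a saturated chain carbon, two bonds along the chain from an oxygen on an aromatic ring so that 2-hydroxyethoxy becomes 3-hydroxypropoxy. Within the data shown here, the only measured step that bears on this is a step that the limit leaves unreadable from compound 2 to compound 3 and it offers no size to carry over. The expectation therefore leans on compound 2 with 539000 nM in the same read-out. In this assay the expected step is a step that the limit leaves unreadable from compound 3 to compound 4 with no clear direction and nothing expected beyond the usual scatter. Compound 4 is estimated at 400000 nM with 180000 nM to 800000 nM as the expected range.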

Compound 4, half-maximal cytotoxic concentration: > 300000 nM
Compound 4: no number, only a limit (the forecaster's own chance of this, stated with the estimate: 55%); the middle value does not contradict the limit.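

Compound 3 and compound 4 both give only a limit of the assay, so no step among them, or from compound 2 to either, can be read in this assay: the limit of > 300000 nM in this assay, at which 2 of the 4 values shown sit.
From the compounds shown here alone, whether 2-hydroxyethoxy and 3-hydroxypropoxy differ at all in this assay stays open.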